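A few compounds are considered here, and "the series" means these few. Any claim that something is new, unique, unknown or untested is made for them only; others in the source may bear on it.

Working notes on the series. The set comprises two measured chalcone-type compounds sharing one core: compound 1 `O=C(/C=C/c1cccc(O)c1)c1cccc(-n2cc(-c3ccc(Cl)cc3)[nH]c2=O)c1` and compound 2 `COc1ccc(-c2cn(-c3cccc(C(=O)/C=C/c4ccc(O)c(OC)c4)c3)c(=O)[nH]2)cc1`. In a functional assay on SW-620 cells (Homo sapiens) for inhibition (a lower number here means a stronger inhibitor of growth, a higher number a weaker inhibitor of growth), compound 1 gives 1620 nM, and in this assay compound 2 gives 2500 nM. The two numbers lie within the usual scatter of each other, so compound 2 and compound 1 are not told apart by these data; compound 2 merely carries the larger of the two numbers shown.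

The unmeasured compound 3 `COc1cc(/C=C/C(=O)c2cccc(-n3cc(-c4ccc(Cl)cc4)[nH]c3=O)c2)ccc1O` differs from compound 2 in one place: chloro in place of methoxy on an aromatic carbon. Going by the values given here, no pair of measured compounds isolates this change, so its effect in this assay cannot be read from a measured step. With compound 1 at 1620 nM carrying the same chloro group on a different chalcone part, no step beyond the scatter is expected. For compound 3 the expected value in this assay is 1900 nM, with a range of 800 nM to 4500 nM. The step expected is a 1.3-fold lower number from compound 2 to compound 3 (0.12 log units; within the scatter).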

Compound 3, concentration for 50% growth inhibition: 2000 nM
The estimate for compound 3 lay 1.1-fold (0.02 log units) below the measured number; measured number inside the range.
By their numbers in this assay, from the lowest: compounds 1, 3 and 2 (each within the scatter of the next).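

In this assay, the exchange of 4-methoxyphenyl for 4-chlorophenyl now has a measured step (a 1.3-fold lower number from compound 2 to compound 3 (0.10 log units; within the scatter)) and shows that chloro and methoxy, para to a large group, are not told apart at this position. With the chloro group held fixed, the chalcone part also gains a measured step, 4-hydroxy-3-methoxyphenyl in place of 3-hydroxyphenyl (a 1.2-fold higher number from compound 1 to compound 3 (0.09 log units; within the scatter)), and these two aryl groups are not told apart either. No evidence is available that bears on this result.

Going by these compounds, each of the two sites rests on a single exchange, so it remains open whether any other group, such as an amine or a carboxylic acid at the chloro position, would separate from chloro and methoxy. The compounds shown also leave open whether the two sites act independently, since no compound pairs 3-hydroxyphenyl with 4-methoxyphenyl under a matched comparison beyond compound 2 and compound 3.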